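Dithiocarbamate series on the shared lactone core: compound 3 to 4

A few compounds are considered here, and "the series" means these few. Any claim that something is new, unique, unknown or untested is made for them only; others in the source may bear on it.

Measured so far in a functional assay on PC-3 cells (Homo sapiens) for antiproliferative activity, read by MTT assay, with a stated time of 72 h; a higher number here means a weaker inhibitor, a lower number a stronger inhibitor:
compound 1, `CC(C)(C)c1ccc(/C=C/C(=O)c2ccc(OCC(=O)N[C@H]3CCOC3=O)cc2)cc1`, gives 10600 nM
compound 2, `O=C(CNc1ccccc1)N[C@H]1CCOC1=O`, gives only a limit, > 64000 nM
compound 3, `O=C1OCC[C@@H]1NC(=S)SCCOc1ccccc1[N+](=O)[O-]`, gives 24000 nM

Among the two numbers that are not limits, compound 3 carries the highest one; its nearest neighbour is compound 1, whose number is lower by a margin beyond the usual scatter. The limit of compound 2 is a limit of this assay and not a number. the limit of > 64000 nM in this assay, at which 1 of the 3 values shown sits.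

Compound 4, `O=C1OCC[C@@H]1NC(=S)SCCOc1ccccc1Cc1ccccc1`, remains to be measured in this assay. It differs from compound 3 in one place: benzyl in place of nitro on an aromatic carbon. Among the compounds with values here, no measured pair shows this change, so the direction is uncertain; a small step toward a lower number is expected, at or just beyond the scatter. For compound 4 the estimate is 15000 nM, between 5000 nM and 50000 nM, meaning an expected step of a 1.6-fold lower number from compound 3 to compound 4 (0.20 log units; within the scatter).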

Compound 4, half-maximal inhibitory concentration: > 64000 nM
Compound 4 ended at the assay's limit; the forecaster's own chance of this, stated with the estimate: 10%; middle value at least 4.2-fold (0.63 log units) away from the limit.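

In this assay, benzyl in place of nitro on an aromatic carbon, ortho to a large group, gives an at least 2.6-fold higher number from compound 3 to compound 4 (0.42 log units; beyond the scatter), the first step read at this position. Compound 4 gives > 64000 nM, which is a limit of the assay and not a number, so the full size of the step stays unread. Compound 2 and compound 4 both sit there: the limit of > 64000 nM in this assay, at which 2 of the 4 values shown sit.

Open, as far as these compounds go, is whether an amine or a carboxylic acid on this aromatic carbon would stay near compound 3 or also reach the limit. This single pair cannot separate the loss of nitro from the arrival of benzyl.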